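The source may report more compounds than this note shows. Statements on the series, on what has been measured and on what is new or still open speak of the compounds shown alone.

Compound 1 `CC(C)(N)C(=O)N[C@H](COCc1ccccc1)c1nnnn1CCCc1ccccc1`: 17 nM in a functional assay on H4 cells for agonist activity at growth hormone secretagogue receptor type 1 (Homo sapiens), read by FLIPR; on this read-out lower numbers stand for an effect already at smaller amounts and higher numbers for an effect only at larger amounts of compound
Compound 2 `CC(C)(N)C(=O)N[C@H](COCc1ccccc1)c1nnnn1CCC#N`: 30 nM in this assay
Compound 3 `COC(=O)CCCn1nnnc1[C@@H](COCc1ccccc1)NC(=O)C(C)(C)N`: 55 nM in this assay

Among the measured compounds shown here, of these three numbers, compound 3 has the highest, though its gap to compound 2 lies within the scatter; only the step of a 3.2-fold higher number from compound 1 to compound 3 (0.51 log units; beyond the scatter) reaches beyond it. Compound 4 `CC(C)(N)C(=O)N[C@H](COCc1ccccc1)c1nnnn1CCC(=O)NCc1ccccc1` is not yet measured. It differs from compound 3 in one place: benzylcarbamoyl in place of (methoxycarbonyl)methyl on a saturated chain carbon, two bonds along the chain from an aromatic nitrogen. For the measured compounds named here, two measured steps bear on this. The step of a 3.2-fold higher number from compound 1 to compound 3 (0.51 log units; beyond the scatter) shows that taking the phenyl ring off the chain raised the number modestly, and the step of a 1.8-fold higher number from compound 2 to compound 3 (0.26 log units; within the scatter) shows that the chain without a ring stays in the same range whichever small group ends it. Compound 4 returns a phenyl ring to the chain, now carried on an amide, so the change is expected to move the number back toward compound 1, without going beyond it. The expected step is a 2.2-fold lower number from compound 3 to compound 4 (0.34 log units; beyond the scatter). For compound 4 the estimate in this assay is 25 nM, within 8 nM to 80 nM.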

Compound 4, half-maximal effective concentration: 51 nM
Compound 4: middle estimate off by 2.0-fold (0.31 log units), on the low side, and the stated range covers the measured number.
By their numbers in this assay, from the lowest: compounds 1, 2, 4 and 3 (each within the scatter of the next, the first and the last beyond it).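

Putting a phenyl ring back on the chain as benzylcarbamoyl does not bring the number back to that of compound 1. In this assay the change gives a 1.1-fold lower number from compound 3 to compound 4 (0.03 log units; within the scatter) and sits close to the chain ending in nitrile with a 1.7-fold higher number from compound 2 to compound 4 (0.23 log units; within the scatter) while the gap to the plain phenyl chain remains at a 3.0-fold higher number from compound 1 to compound 4 (0.48 log units; beyond the scatter). At this position, then, having a phenyl ring somewhere on the chain is not enough to match compound 1, and nothing measured here explains this result.

The compounds shown leave open whether a benzyl ester in place of the amide would fall nearer compound 1 or stay with compound 4. A phenyl ring on a longer plain carbon chain, or a chain ending in an amine or a carboxylic acid, also remains an open case.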